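The compounds below may be only part of what the source reports. "The series", "measured", "known", "first", "only" and "open" are said of these compounds alone.

In a functional assay on HeLa cells (Homo sapiens) for cytotoxicity, read by MTT assay, with a stated time of 48 h (on this read-out higher numbers stand for weaker inhibition and lower numbers for stronger inhibition), compound 1 `COc1ccc(C(C2=C(O)C(=O)c3ccccc3C2=O)c2c[nH]c3ccccc23)cc1Br` gives 7320 nM. Compound 2 `O=C1C(O)=C(C(c2ccc([N+](=O)[O-])cc2)c2c(-c3ccccc3)[nH]c3ccccc23)C(=O)c2ccccc21` gives 6770 nM and compound 3 `O=C1C(O)=C(C(c2cccc([N+](=O)[O-])c2)c2c(-c3ccccc3)[nH]c3ccccc23)C(=O)c2ccccc21` gives 12500 nM, so compound 1 stands second highest of the three numbers, all of which lie within the scatter of one another. Compound 4 `O=C1C(O)=C(C(c2cccs2)c2c[nH]c3ccccc23)C(=O)c2ccccc21` differs from compound 1 by thiophen-2-yl in place of 3-bromo-4-methoxyphenyl on a saturated chain carbon bound to an aromatic carbon and a double-bonded ring carbon. Going by the values given here, the only measured step that bears on it is a 1.8-fold higher number from compound 2 to compound 3 (0.27 log units; within the scatter), an exchange of one aromatic group for another on a saturated chain carbon bound to an aromatic carbon and a double-bonded ring carbon, and it stayed within the scatter. One therefore expects no step beyond the scatter, estimated as a 1.1-fold higher number from compound 1 to compound 4 (0.04 log units; within the scatter). Compound 4 is expected to give 8000 nM, within a range of 3000 nM to 22000 nM.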

Compound 4, half-maximal inhibitory concentration: 12400 nM
The estimate for compound 4 lay 1.6-fold (0.19 log units) below the measured number, within the range that was stated.
By their numbers in this assay, from the lowest: compounds 2, 1, 4 and 3 (each within the scatter of the next).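

In this assay, the exchange at this saturated chain carbon replaces the whole aromatic group rather than moving a nitro group around the same ring, and the result is a 1.7-fold higher number from compound 1 to compound 4 (0.23 log units; within the scatter). The six-membered carbon ring with its bromine and methoxy can thus give way to a five-membered ring with one hetero atom without a step beyond the scatter. Nothing available explains this result. From the compounds shown here alone, what an open alkyl chain or an amine at this place would give remains open, as does whether any group here can move the number beyond the scatter.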